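Compound 1 to compound 4: one number, two limits

The source may report more compounds than this note shows. Statements on the series, on what has been measured and on what is new or still open speak of the compounds shown alone.

Measured so far in a functional assay on SGC-7901 cells (Homo sapiens) for antiproliferative activity, read by MTT assay, with a stated time of 24 h; on this read-out lower numbers stand for stronger inhibition and higher numbers for weaker inhibition
Compound 1 `O=C(NNc1cccc(Cl)c1)c1ccc(NS(=O)(=O)c2cnc(O)nc2O)cc1` gives 11600 nM
Compound 2 `Cc1cccc(NNC(=O)c2cccc(NS(=O)(=O)c3cnc(O)nc3O)c2)c1` gives > 20000 nM (a limit)
Compound 3 `O=C(NNc1ccccc1F)c1cccc(NS(=O)(=O)c2cnc(O)nc2O)c1` gives > 20000 nM (a limit)

Compound 1 is the only one of these with a true number, 11600 nM in this assay. Compound 2 and compound 3 stand at the limit of > 20000 nM in this assay, at which 2 of the 3 values shown sit, and such a limit is not a number.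

Compound 4 `O=C(NNC(=O)c1ccccc1Cl)c1ccc(NS(=O)(=O)c2cnc(O)nc2O)cc1` keeps the core of compound 1 and changes one group ((2-chlorophenyl)carbonyl in place of 3-chlorophenyl on an amine nitrogen). Within the data shown here, the only measured step at an amine nitrogen is a step that the two limits leave unreadable from compound 2 to compound 3, so it offers no size to carry over. Among the measured compounds shown here, no measured step adds a carbonyl there. The expectation therefore starts from compound 1 at 11600 nM. The two limits of compound 2 and compound 3 tilt the expectation towards weaker inhibition.

The expected change is a 1.4-fold higher number from compound 1 to compound 4 (0.14 log units; within the scatter), a small weakening that should stay within the usual scatter. Compound 4 is estimated at 16000 nM, with an expected range from 6000 nM to 40000 nM.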

Compound 4, half-maximal inhibitory concentration: 3240 nM
Compound 4: middle estimate off by 4.9-fold (0.69 log units), on the high side; measured number outside the range, below it.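

In this assay, among these compounds, (2-chlorophenyl)carbonyl in place of 3-chlorophenyl on an amine nitrogen gives a 3.6-fold lower number from compound 1 to compound 4 (0.55 log units; beyond the scatter), which means stronger inhibition and is the first readable size of a change at this position. Among the compounds shown here, the earlier compounds could not give such a size, because the only step among them cannot be read: the limit of > 20000 nM in this assay, at which 2 of the 4 values shown sit. The new step also changes two things at once, adding a carbonyl and carrying the chlorine at the 2-position of the ring instead of the 3-position, so it cannot credit the gain to either one alone.

A (3-chlorophenyl)carbonyl group on the same nitrogen would separate those two changes. As far as these compounds go, whether the chlorine matters at all remains open too, and an unsubstituted benzoyl group or a small acetyl group at this place would bear on that question.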